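The source may report more compounds than this note shows. Statements on the series, on what has been measured and on what is new or still open speak of the compounds shown alone.

Compound 1 `O=C(NCc1cc(Cl)ccc1-n1cnnn1)[C@@H]1CC=NN1C(=O)[C@H](O)c1ccccc1` and compound 2 `CC(C)(C)C[C@@H](O)C(=O)N1N=CC[C@H]1C(=O)NCc1cc(Cl)ccc1-n1cnnn1` share one core; compound 3 `O=C(NCc1cc(Cl)ccc1-n1cnnn1)[C@@H]1C[C@H]2C[C@H]2N1C(=O)[C@H](O)c1ccccc1` and compound 4 `CC(C)(C)C[C@@H](O)C(=O)N1[C@@H]2C[C@@H]2C[C@H]1C(=O)NCc1cc(Cl)ccc1-n1cnnn1` share another, and how the two cores differ is not broken down here. In a functional assay on a cell-free system (plasma, Homo sapiens), with a stated time of 3 min (a higher number here means a weaker inhibitor, a lower number a stronger inhibitor), compound 1 gives 840 nM, compound 2 gives 590 nM and compound 3 gives 680 nM. The change from compound 1 to compound 2 is neopentyl in place of phenyl on a saturated chain carbon bound to a carbonyl carbon and an oxygen on a saturated carbon and made a 1.4-fold lower number from compound 1 to compound 2 (0.15 log units; within the scatter). The change from compound 3 to compound 4 is neopentyl in place of phenyl on a saturated chain carbon bound to a carbonyl carbon and an oxygen on a saturated carbon, the same change at the same place, so compound 3 and compound 4 are a second pair carrying it. Going by the values given here, for compound 4 the step is expected to be about a 1.4-fold lower number from compound 3 to compound 4 (0.15 log units; within the scatter), resting on the single earlier instance in compound 1 and compound 2 with a 1.4-fold lower number from compound 1 to compound 2 (0.15 log units; within the scatter). Compound 4 in this assay is therefore estimated at 480 nM, with a range of 250 nM to 900 nM expected.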

Compound 4, half-maximal inhibitory concentration: 520 nM
The estimate for compound 4 lay 1.1-fold (0.03 log units) below the measured number; low and high end bracket the measured number.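

In this assay, neopentyl in place of phenyl gives a 1.3-fold lower number from compound 3 to compound 4 (0.12 log units; within the scatter), and the step reads alike on both cores: the same change on two cores in this assay, a 1.4-fold lower number (0.15 log units; within the scatter) from compound 1 to compound 2 and a 1.3-fold lower number (0.12 log units; within the scatter) from compound 3 to compound 4, 1.1-fold (0.04 log units) apart, within the scatter of two such steps. The change therefore carries from the core of compound 1 to the core of compound 3 without a difference that can be told from scatter. Since each step itself lies within the scatter, this does not show that neopentyl and phenyl differ in this assay, nor that a real effect has been transferred.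

The compounds shown leave open whether another group on this saturated chain carbon, such as an amine, a carboxylic acid or a longer chain, would move the number beyond the scatter. From the compounds shown here alone, how the change behaves on any further core also remains open.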